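A few compounds are considered here, and "the series" means these few. Any claim that something is new, unique, unknown or untested is made for them only; others in the source may bear on it.

Of the compounds shown here, two have so far been tested in an assay on isolated protein for inhibition of protein deacetylase HDAC6 (Homo sapiens), read by fluorescence, with stated times of 5 min and 30 min; a lower number here means a stronger inhibitor, a higher number a weaker inhibitor. Compound 1, `CNc1nc(Nc2cnn(CCCCCCC(=O)NO)c2)ncc1Cl`, gives 29 nM in this assay. Compound 2, `O=C(CCCCn1cc(Nc2ncc(Cl)c(Nc3ccc(F)cc3)n2)cn1)NO`, gives 310 nM in this assay. Compound 2 therefore carries the higher of the two numbers; its nearest neighbour is compound 1, and the gap between them lies beyond the usual scatter. The two differ at more than one place, so no single step can be read between them.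

Compound 3, `O=C(CCCCCCCn1cc(Nc2ncc(Cl)c(Nc3ccc(F)cc3)n2)cn1)NO`, has not yet been measured. It differs from compound 2 by 3-(hydroxycarbamoyl)propyl in place of hydroxycarbamoyl on a saturated chain carbon, four bonds along the chain from an aromatic nitrogen. Since compound 1, with its value of 29 nM, shows that a lower number is reachable within this core, compound 3 is expected to move in that direction, with a step of a 6.9-fold lower number from compound 2 to compound 3 (0.84 log units; beyond the scatter) that should exceed the scatter. Compound 3 is thus estimated at 45 nM, within a range from 15 nM to 140 nM.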

Compound 3, half-maximal inhibitory concentration: 300 nM
Estimate against measurement, compound 3: 6.7-fold (0.82 log units) below, and the stated range ends below it.
By their numbers in this assay, from the lowest: compound 1; then compounds 3 and 2 (each within the scatter of the next).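

In this assay, for the compounds shown here, 3-(hydroxycarbamoyl)propyl in place of hydroxycarbamoyl on a saturated chain carbon, four bonds along the chain from an aromatic nitrogen, gives a first readable step at this position (a 1.0-fold lower number from compound 2 to compound 3 (0.01 log units; within the scatter)). With the rest of the structure held constant, this lengthening of the chain therefore leaves the number unchanged within the scatter, something the earlier pair could not show, since its two members differ at more than one place. Nothing at hand explains why these two chain lengths read alike.

The two end points leave open how chains of intermediate length, such as 2-(hydroxycarbamoyl)ethyl extended to 5-(hydroxycarbamoyl)pentyl, or a still longer chain would read on this core. They also leave open what a carboxylic acid in place of the hydroxycarbamoyl end would give.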